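The compounds below may be only part of what the source reports. "The series", "measured", "known", "first", "only" and "open" are said of these compounds alone.

Compound 3, `CCCCCCCCSc1nc(N)nc2c1ncn2/C=C1/CC1(CO)CO`, was tested in an ADME assay on BCBL1 cells (Homo sapiens) for cytotoxicity, with a stated time of 7 days; on this read-out higher numbers stand for lower toxicity in this test and lower numbers for higher toxicity in this test. In this assay compound 3 gives only a limit, > 20000 nM. Two close relatives were measured alongside it. Compound 1, `CCCCCCCCOc1nc(N)nc2c1ncn2/C=C1/CC1(CO)CO`, gives a limit as well, > 20000 nM. Compound 2, `CCCSc1nc(N)nc2c1ncn2/C=C1/CC1(CO)CO`, likewise gives a limit, > 20000 nM. Compound 4, `CCCCOc1nc(N)nc2c1ncn2/C=C1/CC1(CO)CO`, has not yet been measured; it differs from compound 3 by butoxy in place of octylsulfanyl on an aromatic carbon. For the measured compounds named here, the steps that bear on this change, a step that the two limits leave unreadable from compound 1 to compound 3 and a step that the two limits leave unreadable from compound 2 to compound 3, cannot be sized, since every value sits at the limit of > 20000 nM in this assay, at which 3 of the 3 values shown sit. No step beyond the scatter is therefore expected in this assay. Compound 4 is expected at 30000 nM, in the range 15000 nM to 100000 nM. The expected step is a step that the limit leaves unreadable from compound 3 to compound 4, most likely reported again only as a limit.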

Compound 4, half-maximal cytotoxic concentration: > 20000 nM
Compound 4: a limit, no number; the forecaster's own chance of this, stated with the estimate: 85%; the middle value is on the limit's open side.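

In this assay compound 4 gives only a limit, as do compounds 1, 2 and 3, so no step among these four compounds can be read: the limit of > 20000 nM in this assay, at which 4 of the 4 values shown sit. On these data alone, whether swapping the group on the aromatic carbon changes the read-out at all stays open.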